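The compounds below may be only part of what the source reports. "The series", "measured", "known", "first", "only" and "open" are said of these compounds alone.

Measured compounds:
Compound 1 `CC(=O)c1ccc(NC(=O)Nc2cc(C)nc3ccccc23)cc1`: > 25000 nM (a limit)
Compound 2 `COC(=O)c1ccc(NC(=O)Nc2cc(C)nc3ccccc23)cc1`: 17000 nM

Among the measured compounds shown here, in an ADME assay on Raji cells (Homo sapiens) for cytotoxicity, with a stated time of 72 h (a lower number here means that less compound is needed, a higher number that more compound is needed for the effect), compound 2 gives 17000 nM, the only actual number so far. Compound 1 gives > 25000 nM, which is a limit of the assay. Compound 3 `Cc1cc(NC(=O)Nc2ccc(C(F)(F)F)cc2)c2ccccc2n1` differs from compound 2 by trifluoromethyl in place of methoxycarbonyl on an aromatic carbon. For the measured compounds named here, the one measured step, an at least 1.4-fold lower number from compound 1 to compound 2 (0.16 log units; that floor lies within the scatter), is methoxy in place of methyl on a carbonyl carbon, and it does not involve trifluoromethyl, so it bears only loosely on this change. The expected step is a 1.2-fold lower number from compound 2 to compound 3 (0.08 log units; within the scatter), with none expected beyond the scatter. Compound 3 is estimated at 14000 nM. The estimated range for compound 3 runs from 5000 nM to 25000 nM.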

Compound 3, half-maximal effective concentration: 23000 nM
For compound 3 the middle estimate is 1.6-fold (0.22 log units) below the measured one, and the stated range covers the measured number.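

At this aromatic carbon, trifluoromethyl replaces methoxycarbonyl, which has the same number of heavy atoms, and this assay shows a 1.4-fold higher number from compound 2 to compound 3 (0.13 log units; within the scatter). The other comparison at this carbon, with acetyl leaving, gives only a floor within the scatter: an at least 1.0-fold lower number from compound 1 to compound 3 (0.03 log units; that floor lies within the scatter). Compound 1 carries a limit and not a number: the limit of > 25000 nM in this assay, at which 1 of the 3 values shown sits. The compounds shown leave open whether an amine or a carboxylic acid on this aromatic carbon would shift the number beyond the scatter. They also leave open whether changes elsewhere on the shared core would do so.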